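Methyl for chloro on the N-benzylated core

The source may hold more compounds than are shown below. What is called first, only, known or untested is meant among the compounds shown, and "the series" means these compounds.

Within the data shown here, compound 2 `O=C1/C(=N\NC(=S)Nc2ccc(Cl)cc2)c2cc(F)ccc2N1Cc1ccc(F)cc1` is the weaker of the two measured compounds in a functional assay on CCRF-CEM cells (Homo sapiens), with a stated time of 72 h (on this read-out lower numbers stand for stronger inhibition and higher numbers for weaker inhibition), where compound 2 gives 56000 nM, the highest of the two numbers known so far. Compound 1 `Cc1ccc(NC(=S)N/N=C2\C(=O)Nc3ccc(F)cc32)cc1`, which carries an unsubstituted ring nitrogen and a tolyl group, gives 4800 nM in this assay. Compound 3 `Cc1ccc(NC(=S)N/N=C2\C(=O)N(Cc3ccc(F)cc3)c3ccc(F)cc32)cc1` keeps the substituted core of compound 2 and changes only the aryl group on the thiourea: methyl in place of chloro on an aromatic carbon, a methyl in place of chloro on an aromatic carbon, para to a large group. Among the measured compounds shown here, no measured pair isolates this exchange, so its effect is not known from the data. It is expected to be a small step, probably a slight move toward lower numbers but not beyond the scatter, so compound 3 is estimated at 40000 nM, within 12000 nM to 140000 nM, meaning an expected step of a 1.4-fold lower number from compound 2 to compound 3 (0.15 log units; within the scatter).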

Compound 3, half-maximal inhibitory concentration: 2500 nM
Compound 3: middle estimate off by 16-fold (1.20 log units), on the high side; the measured number lies below the stated range.
By their numbers in this assay, from the lowest: compounds 3 and 1 (each within the scatter of the next); then compound 2.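

In this assay, methyl in place of chloro on an aromatic carbon, para to a large group, proves a large exchange on the core carrying the 4-fluorobenzyl group (a 22-fold lower number from compound 2 to compound 3 (1.35 log units; beyond the scatter)). With the 4-methylphenyl group held constant, 4-fluorobenzyl in place of hydrogen on the amide-type nitrogen in a ring leaves the number within the scatter (a 1.9-fold lower number from compound 1 to compound 3 (0.28 log units; within the scatter)), so the two changes do not read alike in this set. Nothing measured here accounts for the size of the chloro to methyl step.

The compounds shown do not tell whether chloro and methyl differ as widely on the core that keeps the amide hydrogen. Nor do they say how other groups in that place, such as methoxy, an amine or a carboxylic acid, would read.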